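The source may hold more compounds than are shown below. What is called first, only, known or untested is meant among the compounds shown, and "the series" means these compounds.

Measured compounds, with their results in an assay on isolated protein for inhibition of DNA topoisomerase 1 (Homo sapiens), with a stated time of 30 min, tested at 100 uM; on this read-out lower numbers stand for a weaker effect and higher numbers for a stronger effect at the one concentration tested:

- compound 1 `CN(C)c1ccc2nc(-c3cccc4ccccc34)[nH]c(=O)c2c1`, compound 1 gives 100%
- compound 2 `Cc1ccc2c(=O)[nH]c(-c3ccccc3C)nc2c1`, compound 2 gives 100%
- compound 3 `Cc1ccc2nc(-c3cccc(C(F)(F)F)c3)[nH]c(=O)c2c1`, compound 3 gives 45.8%

Compound 1 and compound 2 return the same number at the digits reported, so no order between them can be read, and the two together stand at the top of these three readings. Compound 3 lies well below compound 1, a gap that is beyond the usual scatter of such measurements.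

The next compound, compound 4 `O=c1[nH]c(-c2cccc3ccccc23)nc2ccc(N3CCCCC3)cc12`, has not yet been tested. It keeps the whole of compound 1 apart from one change: piperidin-1-yl in place of dimethylamino on an aromatic carbon. The new group sits on an aromatic carbon of a six-membered aromatic ring of carbon only, within a fused system of two rings, exactly where the old one was. One small amine is swapped for a larger ring-shaped amine at the same spot. Since compound 1 already reads at the full scale in this assay, any step can only go downward or stay flat. A step of a number 8 percentage points lower from compound 1 to compound 4 (within the scatter) is expected, essentially none beyond the scatter. For compound 4 the estimated value in this assay is 92%, with a likely range from 65% to 100%.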

Compound 4, a percentage reported as inhibition, at one concentration (the size of the read-out at that concentration, not a potency): 100%
Compound 4: the middle estimate sits 8 percentage points below what was measured; the measured number falls inside the stated range.
By their numbers in this assay, from the lowest: compound 3; then compounds 1, 2 and 4 (each within the scatter of the next).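

In this assay the swap of dimethylamino for piperidin-1-yl on this aromatic carbon gives no change at the digits printed from compound 1 to compound 4 (within the scatter) and so shows that this position accepts a larger, ring-shaped amine with no drop in the reading. The earlier compounds shown here could not show this, as none of them formed a one-change pair. Both compounds of this pair sit at the top of the scale at the single concentration tested, so the reading cannot tell whether the two amines truly match or one is stronger than the other. Nothing available explains why the reading stays flat.

Still open, on these data alone, is how a morpholine ring, a primary amine or a carboxylic acid on this same aromatic carbon would read. Also open, as far as these compounds go, is how compound 1 and compound 4 would compare at a lower concentration, where the top of the scale no longer hides a difference.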